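Trimming a Side Chain on Two Related Cores

The source may hold more compounds than are shown below. What is called first, only, known or untested is meant among the compounds shown, and "the series" means these compounds.

Compound 3 `CCCCCCCCCCn1cc(-c2nc3ccccc3cc2CCCCC)nn1` and compound 1 `CCCCCCCCCCn1cc(-c2nc3ccccc3cc2CC)nn1` share one core and differ by hydrogen in place of propyl on a saturated chain carbon, two bonds along the chain from an aromatic carbon. In a functional assay on THP-1 cells (Homo sapiens) for cytotoxicity, read by MTT assay, with a stated time of 24 h (a higher number here means a weaker inhibitor, a lower number a stronger inhibitor), compound 3 gives 88 ug/mL, and compound 1 gives 34.3 ug/mL, so a 2.6-fold lower number from compound 3 to compound 1 (0.41 log units; beyond the scatter). Compound 2 `CCCCCc1cc2ccccc2nc1-c1cn(CCC(F)(F)C(F)(F)C(F)(F)C(F)(F)C(F)(F)C(F)(F)C(F)(F)C(F)(F)F)nn1` carries a different core, and the difference between the two cores is not broken down here. In this assay compound 2 gives only a limit, > 100 ug/mL, and the limit of > 100 ug/mL in this assay, at which 1 of the 3 values shown sits, is where its value sits. Compound 4 `CCc1cc2ccccc2nc1-c1cn(CCC(F)(F)C(F)(F)C(F)(F)C(F)(F)C(F)(F)C(F)(F)C(F)(F)C(F)(F)F)nn1` is yet to be measured in this assay and differs from compound 2 by hydrogen in place of propyl on a saturated chain carbon, two bonds along the chain from an aromatic carbon, the same change as that between compound 3 and compound 1. The step of an at least 1.1-fold lower number from compound 2 to compound 4 (0.04 log units; that floor lies within the scatter) is expected to be of similar size to the earlier step, resting on a 2.6-fold lower number from compound 3 to compound 1 (0.41 log units; beyond the scatter). Compound 4 is therefore expected to give about 90 ug/mL, estimated between 40 ug/mL and 200 ug/mL.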

Compound 4, half-maximal inhibitory concentration: > 100 ug/mL
Compound 4 gave a limit, no number; the forecaster's own chance of this, stated with the estimate: 40%; middle value at least 1.1-fold (0.04 log units) from the limit.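

In this assay, among these compounds, compound 4 gives only a limit, > 100 ug/mL, so with compound 2 also at a limit, no step between them can be read. As far as these compounds go, whether pentyl to ethyl shifts the number on this core, as it does from compound 3 to compound 1, stays open.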